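A few compounds are considered here, and "the series" means these few. Any claim that something is new, unique, unknown or untested is made for them only; others in the source may bear on it.

Compound 1 `C#CCN1CCC(OC(=O)Nc2ccc(C(C)C)cc2)CC1` was examined in an assay on BTI-TN-5B1-4 cells for inhibition of Amine oxidase [flavin-containing] A (Homo sapiens), read by fluorescence and Amplex Red, using microsomes, with a stated time of 15 min; a higher number here means a weaker inhibitor, a lower number a stronger inhibitor. Compound 1 gives only a limit there, > 100000 nM. Compound 2 `CC(C)c1ccc(NC(=O)OC2CCN(Cc3ccccc3)CC2)cc1` likewise gives only a limit in this assay, > 100000 nM. The change from one to the other is phenyl in place of ethynyl on a saturated chain carbon bound to an amine nitrogen in a ring, and its step, a step that the two limits leave unreadable from compound 1 to compound 2, cannot be sized from two limits. Compound 3 `C#CCN1CCC(COC(=O)N(C)CC)CC1` rests on a different core, and the difference between the two cores is not broken down here. In this assay compound 3 also gives only a limit, > 100000 nM. Compound 4 `CCN(C)C(=O)OCC1CCN(Cc2ccccc2)CC1` carries the same change on the core of compound 3, (phenyl in place of ethynyl on a saturated chain carbon bound to an amine nitrogen in a ring). Within the data shown here, the only evidence is the limit of > 100000 nM in this assay, at which 3 of the 3 values shown sit. Since the earlier step that the two limits leave unreadable from compound 1 to compound 2 is unreadable, the expected step is a step that the limit leaves unreadable from compound 3 to compound 4. Compound 4 is therefore estimated at 150000 nM, expected to lie between 30000 nM and 1000000 nM.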

Compound 4, half-maximal inhibitory concentration: > 100000 nM
Compound 4: only a limit was reported; the forecaster's own chance of this, stated with the estimate: 80%; the middle value lies beyond the limit too.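

Among these compounds, compound 3 and compound 4 both give only limits, so no step between them can be read. The compounds shown leave open what phenyl in place of ethynyl does on either core in this assay and whether any of them gives a number there: the limit of > 100000 nM in this assay, at which 4 of the 4 values shown sit.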